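This account rests on a few compounds, and the source may have more. Where it says the series, first, only, none or still open, it means among the compounds named here.

Of the compounds shown here, three sharing one core have been measured in a functional assay on RT-112 cells (Homo sapiens) for antiproliferative activity, read by MTT assay, with a stated time of 72 h; on this read-out higher numbers stand for weaker inhibition of growth and lower numbers for stronger inhibition of growth. Compound 1 `COc1cc(Nc2ncnc3c(NC(=O)Nc4ccc(C)c(C)c4)cccc23)cc(OC)c1` gives 8.8 nM and stands lowest of the three numbers. Compound 2 `COc1cc(Nc2ncnc3c(NC(=O)Nc4cccc(Cl)c4Cl)cccc23)cc(OC)c1` gives 63.2 nM, and compound 3 `COc1cc(Nc2ncnc3c(NC(=O)Nc4cc(Cl)cc(Cl)c4)cccc23)cc(OC)c1` gives 30.2 nM. The steps among them are modest: a 7.2-fold higher number from compound 1 to compound 2 (0.86 log units; beyond the scatter), a 3.4-fold higher number from compound 1 to compound 3 (0.54 log units; beyond the scatter) and a 2.1-fold lower number from compound 2 to compound 3 (0.32 log units; beyond the scatter), so exchanging the substituents on the aryl group attached to the amide-type nitrogen moves the number beyond the scatter but not by much.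

Compound 4 `COc1cc(Nc2ncnc3c(NC(=O)c4ccc(CN(C)C)cc4)cccc23)cc(OC)c1` departs from compound 1 differently: 4-((dimethylamino)methyl)phenyl in place of (3,4-dimethylphenyl)amino on a carbonyl carbon. The aryl group is now joined directly to the carbonyl carbon, and the carried group changes at the same time. Within the data shown here, no measured step touches the linkage itself; the three steps above only vary the aryl substituents, and each of them weakened growth inhibition relative to compound 1. Among the measured compounds shown here, on that basis, the step from compound 1 to compound 4 is expected to weaken growth inhibition as well, as a 6.8-fold higher number from compound 1 to compound 4 (0.83 log units; beyond the scatter), with wide uncertainty since no measured pair tests this kind of change. Compound 4 is therefore estimated to give 60 nM in this assay, with a range from 10 nM to 400 nM.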

Compound 4, concentration for 50% growth inhibition: 4370 nM
Beside the measured number, compound 4's estimate is 73-fold (1.86 log units) below it; the measured number lies above the stated range.
By their numbers in this assay, from the lowest: compound 1; then compound 3; then compound 2; then compound 4.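

In this assay the place on the carbonyl carbon proves far less forgiving than the aryl substituents alone had suggested: putting 4-((dimethylamino)methyl)phenyl there in place of (3,4-dimethylphenyl)amino gives a 500-fold higher number from compound 1 to compound 4 (2.70 log units; beyond the scatter) and the matching exchanges give a 140-fold higher number from compound 3 to compound 4 (2.16 log units; beyond the scatter) and a 69-fold higher number from compound 2 to compound 4 (1.84 log units; beyond the scatter) as well. All three steps are large, whereas those among compound 1, compound 2 and compound 3 were modest, so this exchange, which removes the amino nitrogen with its hydrogen-bond donor and brings in a hydrogen-bond acceptor while keeping an aromatic ring of carbon, matters far more than any change of the aryl substituents shown. Nothing measured here accounts for the size of this loss.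

As far as these compounds go, compound 4 changes the linkage and the carried group together, so it remains open whether the loss follows from the aryl group being joined directly to the carbonyl carbon or from the (dimethylamino)methyl group itself. An unsubstituted phenyl on the carbonyl carbon, or a (dimethylamino)methyl or morpholine group on the aryl of the (arylamino) linkage of compound 1, would separate these two changes.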